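Replacing 3-methoxyphenyl with 4-chlorophenyl in the series

The source may hold more compounds than are shown below. What is called first, only, known or untested is meant among the compounds shown, and "the series" means these compounds.

For the measured compounds named here, in a functional assay on HT-29 cells (Homo sapiens) for antiproliferative activity, read by sulforhodamine B assay, with a stated time of 48 h (a lower number here means a stronger inhibitor, a higher number a weaker inhibitor), compound 1 `COc1cccc(OS(=O)(=O)c2ccc(N3CCN(C)C3=O)cc2)c1` gives 2500 nM, the higher of the two numbers so far, while compound 2 `COc1cc(OC)cc(OS(=O)(=O)c2ccc(N3CCN(C)C3=O)cc2)c1` gives 190 nM. Going by the values given here, the only measured step, a 13-fold lower number from compound 1 to compound 2 (1.12 log units; beyond the scatter), is large and comes with methoxy in place of hydrogen on an aromatic carbon.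

Compound 3 `CN1CCN(c2ccc(S(=O)(=O)Oc3ccc(Cl)cc3)cc2)C1=O` has 4-chlorophenyl in place of 3-methoxyphenyl on an oxygen. Among the compounds with values here, the measured step bears on this change only indirectly: it shows that a change on this aromatic ring can move the number strongly, but compound 3 gains no methoxy, and no measured compound carries chlorine. The data therefore give no direction, and no step beyond the scatter is expected in this assay. The estimated step is a 1.3-fold lower number from compound 1 to compound 3 (0.10 log units; within the scatter), with a wide margin of uncertainty. For compound 3 the expected value is 2000 nM, within an estimated range of 600 nM to 7000 nM.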

Compound 3, half-maximal inhibitory concentration: 12000 nM
Compound 3: the middle estimate sits 6.0-fold (0.78 log units) below what was measured; measured number above the stated range.
By their numbers in this assay, from the lowest: compound 2; then compound 1; then compound 3.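

In this assay the exchange of 3-methoxyphenyl for 4-chlorophenyl on an oxygen gives a 4.8-fold higher number from compound 1 to compound 3 (0.68 log units; beyond the scatter) and so shows that the number at this position can also rise, whereas the earlier step showed only a fall on adding methoxy. This change removes the methoxy and brings in chlorine in one step, so the rise cannot be assigned to either event alone. No measurement is available that explains this step.

The compounds shown leave open whether a plain phenyl on the same oxygen would sit nearer to compound 1 or to compound 3, which would help separate the two events. They also leave open how an amine or a carboxylic acid on this aromatic ring would move the number.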